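The source may report more compounds than this note shows. Statements on the series, on what has been measured and on what is new or still open speak of the compounds shown alone.

Compound 2 `COc1ccc2c(c1)C(=O)C=CC2=O` gives in a functional assay on KB cells (Homo sapiens) for cytotoxicity (on this read-out higher numbers stand for weaker inhibition and lower numbers for stronger inhibition), a value of 33900 nM. Compound 1 `CCOC1=CC(=O)c2ccccc2C1=O` gives 16900 nM and compound 3 `CC(=O)OC1=CC(=O)c2ccccc2C1=O` gives 38800 nM. Compound 2 stands second highest of the three numbers; its gap to compound 3 lies within the scatter, and so does its gap to compound 1. Compound 4 `C=CCOc1ccc2c(c1)C(=O)C=CC2=O` differs from compound 2 by vinyl in place of hydrogen on a saturated chain carbon bound to an oxygen on an aromatic ring. Among the measured compounds shown here, the only step between measured compounds, a 2.3-fold higher number from compound 1 to compound 3 (0.36 log units; beyond the scatter), concerns acetyl in place of ethyl on an oxygen on an unsaturated carbon, not the saturated chain carbon bound to an oxygen on an aromatic ring changed here, so it bears only loosely on the step to compound 4; it shows a modest movement when the group on an oxygen of the shared core changes. For the measured compounds named here, no measured pair shows vinyl entering at this place. For compound 4 the expected step is a 1.1-fold lower number from compound 2 to compound 4 (0.05 log units; within the scatter), within the scatter. Compound 4 is thus expected at 30000 nM. The expected range for compound 4 runs from 12000 nM to 75000 nM.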

Compound 4, half-maximal inhibitory concentration: 10200 nM
Compound 4: the middle estimate sits 2.9-fold (0.47 log units) above what was measured, and the stated range ends above it.
By their numbers in this assay, from the lowest: compounds 4, 1, 2 and 3 (each within the scatter of the next, the first and the last beyond it).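

In this assay, the change from methoxy to allyloxy gives a 3.3-fold lower number from compound 2 to compound 4 (0.52 log units; beyond the scatter), so the saturated chain carbon bound to an oxygen on an aromatic ring does respond to the entry of vinyl, and the movement is towards stronger inhibition. Among the compounds shown here, the earlier compounds showed a change only on an oxygen on an unsaturated carbon, so this is the first reading at this place, and it rests on this single pair. Nothing given here accounts for the shift.

Going by these compounds, whether the double bond of the vinyl matters, or only the extension of the chain, stays open, as a propyl group on the same oxygen would be needed to separate the two. On these data alone, how a longer chain, a benzyl group or an amine would read at this place also remains open.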